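Furan-2-yl in Place of Phenyl: An Expected Cytotoxicity Value

The compounds below may be only part of what the source reports. "The series", "measured", "known", "first", "only" and "open" are said of these compounds alone.

Of the compounds shown here, two sharing a common core have been measured in an ADME assay on HEK293 cells (Homo sapiens) for cytotoxicity, read by CCK-8 assay and cell counting, with a stated time of 2 days; on this read-out lower numbers stand for stronger inhibition and higher numbers for weaker inhibition. Compound 1 `Oc1cccc(-c2cc(-c3ccc(Cl)cc3)nc(-c3ccco3)c2)c1` gives 8190 nM in this assay. Compound 2 `Oc1cccc(-c2cc(-c3ccccc3)nc(-c3ccccc3Cl)c2)c1` gives 1760 nM in this assay, the lowest of the two numbers; compound 1 stands at a higher number, and the gap between them lies beyond the usual scatter of such measurements. Because the two structures differ in more than one place, their values show only what each compound does on its own.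

Compound 3 `Oc1cccc(-c2cc(-c3ccco3)nc(-c3ccccc3Cl)c2)c1` has not yet been measured in this assay. It differs from compound 2 in a single place: furan-2-yl in place of phenyl on an aromatic carbon. Going by the values given here, no measured pair isolates this exact change, so its effect is unknown. Still, compound 1, which also carries a furan-2-yl group, gave the higher of the two numbers with 8190 nM. The step from compound 2 to compound 3 is therefore expected to be a 1.7-fold higher number from compound 2 to compound 3 (0.23 log units; within the scatter), a modest move toward a higher number that may well remain within the scatter. Compound 3 is expected to give about 3000 nM, with a range from 1200 nM to 8000 nM.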

Compound 3, half-maximal inhibitory concentration: 1860 nM
Compound 3: the middle estimate sits 1.6-fold (0.21 log units) above what was measured; low and high end bracket the measured number.
By their numbers in this assay, from the lowest: compounds 2 and 3 (each within the scatter of the next); then compound 1.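

In this assay, furan-2-yl in place of phenyl on this aromatic carbon, next to the ring nitrogen, gives a 1.1-fold higher number from compound 2 to compound 3 (0.02 log units; within the scatter), so with a 2-chlorophenyl group on the shared core, the two rings cannot be told apart on this read-out. The furan-2-yl group on its own therefore does not bring a higher number: with that group kept, 2-chlorophenyl in place of 4-chlorophenyl gives a 4.4-fold lower number from compound 1 to compound 3 (0.64 log units; beyond the scatter), a step beyond the scatter, which points to the chlorophenyl group as the place that matters in this small set. No measurement at hand explains why one swap leaves the number in place while the other shifts it.

As far as these compounds go, it remains open whether phenyl and furan-2-yl would also match when 4-chlorophenyl sits on the core, so the result holds only alongside 2-chlorophenyl. Also open, from the compounds shown here alone, is how this aromatic carbon would respond to a group that is not an aromatic ring, such as an amine or a longer carbon chain, and whether a chlorine elsewhere on the phenyl ring would follow either chlorophenyl group.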